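The compounds below may be only part of what the source reports. "The series", "measured", "known", "first", "only" and "open" are said of these compounds alone.

Working notes on the series, read in a functional assay on Raji cells (Homo sapiens) for cytotoxicity, with a stated time of 72 h; on this read-out higher numbers stand for an effect only at larger amounts of compound and lower numbers for an effect already at smaller amounts. Compound 1 `C=C[C@@](C)(/C=C/c1ccc(O)cc1)CCC(O)C(C)(C)O` gives > 26000 nM, which is a limit and not a number. Compound 2 `C=C[C@@](C)(/C=C/c1ccc(Nc2ccccc2)cc1)CCC=C(C)C` gives > 26000 nM, also a limit, so its place on the scale is not fixed. Compound 3 `C=C[C@@](C)(/C=C/c1ccc(Nc2cccc(OC(F)(F)F)c2)cc1)CCC=C(C)C` gives > 26000 nM, again a limit. The evidence so far is the limit of > 26000 nM in this assay, at which 3 of the 3 values shown sit. Compound 4 `C=C[C@@](C)(/C=C/c1ccc(Nc2ccc(Cl)c(F)c2)cc1)CCC=C(C)C` carries 4-chloro-3-fluorophenyl in place of phenyl on a nitrogen on an aromatic ring. Among the compounds with values here, the one measured step bearing on this is a step that the two limits leave unreadable from compound 2 to compound 3, which offers no size or direction to carry over. The expected step is a step that the limit leaves unreadable from compound 2 to compound 4, with no direction supported. For compound 4 the estimate is 30000 nM, expected between 10000 nM and 60000 nM, and probably reported only as a limit.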

Compound 4, half-maximal effective concentration: > 26000 nM
Compound 4: no number, only a limit; the forecaster's own chance of this, stated with the estimate: 80%; the middle value is on the limit's open side.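

Compound 2 and compound 4 are both recorded only as limits, so no step can be read between them. The compounds shown leave open where any of them would fall on the scale of this assay, and whether changing the group on the nitrogen shifts that place.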